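The source may hold more compounds than are shown below. What is called first, only, known or untested is meant among the compounds shown, and "the series" means these compounds.

In a functional assay on SW-620 cells (Homo sapiens) (a higher number here means a weaker inhibitor of growth, a lower number a stronger inhibitor of growth), compound 1 `N#Cc1ccc(/C=C/S(=O)(=O)Cc2ccc(Nc3ncnc4ccccc34)cc2)cc1` gives > 100000 nM, which is a limit of the assay and not a number. Within the data shown here, compound 2 `O=S(=O)(/C=C/c1ccc(Cl)c(Cl)c1)Cc1ccc(Nc2ncnc3ccccc23)cc1` gives 41000 nM, and compound 3 `O=S(=O)(/C=C/c1ccc(Cl)c(Cl)c1)Cc1ccc(Nc2ncnc3ccc(Br)cc23)cc1` gives 5000 nM, the lowest of the numbers so far.

Compound 4 `O=S(=O)(/C=C/c1ccc(O)cc1)Cc1ccc(Nc2ncnc3ccc(Br)cc23)cc1` keeps everything in compound 3 except one group, with 4-hydroxyphenyl in place of 3,4-dichlorophenyl on a double-bonded chain carbon bound to a double-bonded chain carbon. The step that bears most directly on this is an at least 2.4-fold lower number from compound 1 to compound 2 (0.38 log units; beyond the scatter), made at the same place, where 3,4-dichlorophenyl replaced 4-cyanophenyl. Its size is only a minimum, since one end is a limit. The other step, an 8.2-fold lower number from compound 2 to compound 3 (0.91 log units; beyond the scatter), concerns bromo in place of hydrogen, and compound 4 retains that bromo. Among the measured compounds shown here, no 4-hydroxyphenyl compound has yet been measured, so the forecast rests on a single comparison and remains loose. Losing 3,4-dichlorophenyl is expected to raise the number by a modest amount, and the expected change is a 4.0-fold higher number from compound 3 to compound 4 (0.60 log units; beyond the scatter). Compound 4 is estimated at 20000 nM, with an expected range of 6000 nM to 70000 nM.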

Compound 4, concentration for 50% growth inhibition: 94000 nM
Compound 4: middle estimate off by 4.7-fold (0.67 log units), on the low side, outside the stated range (above it).
By their numbers in this assay, from the lowest: compound 3; then compound 2; then compound 4. At a limit, above all of these: compound 1.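

In this assay, 4-hydroxyphenyl in place of 3,4-dichlorophenyl gives a 19-fold higher number from compound 3 to compound 4 (1.27 log units; beyond the scatter). Among these compounds, this is the first step at this place with a measured number at both ends, so its full size can be read, whereas the earlier step here gave only a minimum. Compound 3 and compound 4 both carry the bromo, so that group alone does not keep the number low with 4-hydroxyphenyl at this place, and compound 4 ends up close to the top of what this assay reports: the limit of > 100000 nM in this assay, at which 1 of the 4 values shown sits.

The compounds shown cannot separate the loss of the two chlorines from the arrival of the hydroxyl, since both happen in one step. As far as these compounds go, a plain phenyl, 4-chlorophenyl or 4-methoxyphenyl at this place would tell those two apart, and whether the step keeps its size without the bromo remains open.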